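One aryl swap, carried from one core to another

The source may hold more compounds than are shown below. What is called first, only, known or untested is meant among the compounds shown, and "the series" means these compounds.

Measured in a functional assay on MCF7 cells (Homo sapiens) for cytotoxicity, read by MTT assay, with a stated time of 72 h; a higher number here means a weaker inhibitor, a lower number a stronger inhibitor:
compound 1 `Cc1cc(=O)n(-c2ccc(Br)cc2F)nc1C(=O)Nc1ccc(Oc2ncnc3sccc23)cc1` gives 15200 nM
compound 2 `Cc1cc(=O)n(-c2ccccc2OC(F)(F)F)nc1C(=O)Nc1ccc(Oc2ncnc3sccc23)cc1` gives 11000 nM
compound 3 `Cc1cc(=O)n(-c2ccc(Br)cc2F)nc1C(=O)Nc1ccc(Oc2ncnc3sccc23)c(F)c1` gives 13300 nM

Compound 3 differs from compound 1 in its core by fluoro in place of hydrogen on an aromatic carbon, and in this assay the step is a 1.1-fold lower number from compound 1 to compound 3 (0.06 log units; within the scatter). Compound 2 differs from compound 1 by 2-(trifluoromethoxy)phenyl in place of 4-bromo-2-fluorophenyl on an aromatic nitrogen, with a step of a 1.4-fold lower number from compound 1 to compound 2 (0.14 log units; within the scatter). Compound 4 `Cc1cc(=O)n(-c2ccccc2OC(F)(F)F)nc1C(=O)Nc1ccc(Oc2ncnc3sccc23)c(F)c1` carries the same change on the core of compound 3, namely (2-(trifluoromethoxy)phenyl in place of 4-bromo-2-fluorophenyl on an aromatic nitrogen); the place and its surroundings read the same for both pairs, so this is the same change. The step from compound 3 to compound 4 is expected to be small, about a 1.4-fold lower number from compound 3 to compound 4 (0.15 log units; within the scatter), because a 1.4-fold lower number from compound 1 to compound 2 (0.14 log units; within the scatter) stayed within the scatter on the other core. Compound 4 is therefore estimated at 9500 nM, with a range from 4500 nM to 20000 nM.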

Compound 4, half-maximal inhibitory concentration: > 40000 nM
Compound 4 gave a limit, no number; the forecaster's own chance of this, stated with the estimate: 10%; middle value at least 4.2-fold (0.62 log units) away from the limit.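

Carried to the core of compound 3, the aryl swap gave an at least 3.0-fold higher number from compound 3 to compound 4 (0.47 log units; beyond the scatter), so the change did not transfer between the two cores: the same change on two cores in this assay, a 1.4-fold lower number (0.14 log units; within the scatter) from compound 1 to compound 2 and an at least 3.0-fold higher number (0.47 log units; beyond the scatter) from compound 3 to compound 4, at least 4.1-fold (0.61 log units) apart, beyond the scatter of two such steps

The fluoro change tells the same story from the other side, giving an at least 3.6-fold higher number from compound 2 to compound 4 (0.56 log units; beyond the scatter), so its outcome depended on the aryl group present: the same change on two cores in this assay, a 1.1-fold lower number (0.06 log units; within the scatter) from compound 1 to compound 3 and an at least 3.6-fold higher number (0.56 log units; beyond the scatter) from compound 2 to compound 4, at least 4.1-fold (0.61 log units) apart, beyond the scatter of two such steps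

In this assay compound 4 gives > 40000 nM, a limit and not a number, so the full size of both steps stays unknown, and the compounds shown give no cause for the break.

The compounds shown leave open whether the break belongs to these two aryl groups alone. They also leave open whether a phenyl carrying an amine or a carboxylic acid on the aromatic nitrogen, or chloro in place of the fluoro, would behave alike on both cores.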